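Dropping the hydroxy and methylating the imine carbon

A few compounds are considered here, and "the series" means these few. Any claim that something is new, unique, unknown or untested is made for them only; others in the source may bear on it.

Three thiosemicarbazones sharing one core have been tested in a functional assay on NCI-H460 cells (Homo sapiens) for cytotoxicity, read by sulforhodamine B assay; on this read-out higher numbers stand for weaker inhibition of growth and lower numbers for stronger inhibition of growth. Compound 1 `CC1=CC[C@@H]([C@@](C)(O)CCCC(C)(C)NC(=S)N/N=C\c2ccccc2)CC1` gives 38400 nM. Compound 2 `CC1=CC[C@@H]([C@@](C)(O)CCCC(C)(C)NC(=S)N/N=C\c2ccc(C)cc2)CC1` gives 10100 nM, and compound 3 `CC1=CC[C@@H]([C@@](C)(O)CCCC(C)(C)NC(=S)N/N=C\c2ccc(O)cc2)CC1` gives 1460 nM. The steps are a 3.8-fold lower number from compound 1 to compound 2 (0.58 log units; beyond the scatter), a 26-fold lower number from compound 1 to compound 3 (1.42 log units; beyond the scatter) and a 6.9-fold lower number from compound 2 to compound 3 (0.84 log units; beyond the scatter), so compound 3 stands at the lowest number of the three, with compound 2 nearest and compound 1 furthest away.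

Compound 4 `CC1=CC[C@@H]([C@@](C)(O)CCCC(C)(C)NC(=S)N/N=C(/C)c2ccccc2)CC1` is the next one. Relative to compound 3 the change is a group of 9 heavy atoms (8 carbon, 1 nitrogen; one six-membered aromatic ring of carbon only) in place of a group of 9 heavy atoms (7 carbon, 1 nitrogen, 1 oxygen; one six-membered aromatic ring of carbon only), on an amide-type nitrogen: the hydroxy on the aromatic ring is gone, and a methyl now sits on the imine carbon. Among the compounds with values here, no measured step covers a methyl on that carbon, so that part of the change is an unknown. The loss of the hydroxy, however, is the reverse of the step from compound 1 to compound 3, and that step was large. Compound 4 therefore resembles compound 1 more than compound 3, and its number is expected to move a long way upward in this assay, as a 21-fold higher number from compound 3 to compound 4 (1.31 log units; beyond the scatter). For compound 4 a value of 30000 nM is estimated, within a range from 8000 nM to 100000 nM, the width reflecting the untested methyl.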

Compound 4, concentration for 50% growth inhibition: 12600 nM
For compound 4 the middle estimate is 2.4-fold (0.38 log units) above the measured one, within the range that was stated.
By their numbers in this assay, from the lowest: compound 3; then compounds 2 and 4 (each within the scatter of the next); then compound 1.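

Within the data shown here, the methyl on the imine carbon, the one feature no earlier step covered, can now be read on its own: with the aromatic ring left unsubstituted, this assay shows a 3.0-fold lower number from compound 1 to compound 4 (0.48 log units; beyond the scatter), a modest change beyond the scatter. Placed on the imine carbon, the methyl gives a number that cannot be told apart from that of the methyl on the aromatic ring, with a 1.2-fold higher number from compound 2 to compound 4 (0.10 log units; within the scatter), which lies within the scatter. It does not make up for the missing hydroxy on the aromatic ring, since the comparison with the hydroxy compound gives an 8.6-fold higher number from compound 3 to compound 4 (0.94 log units; beyond the scatter), so the hydroxy compound still holds the lowest number of the four.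

No experimental information here accounts for any of these shifts. As far as these compounds go, it remains open whether a hydroxy on the aromatic ring and a methyl on the imine carbon would add up in a single compound, and how a methoxy or an amine on the ring, or an ethyl on the imine carbon, would read on this assay.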